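The source may report more compounds than this note shows. Statements on the series, on what has been measured and on what is new or still open speak of the compounds shown alone.

Compound 2 `CN(C)C(=O)[C@@H]1CN[C@H](C(=O)N2CCC[C@H]2C#N)C1` gives 76% in an assay on the whole organism (plasma, strain Sprague-Dawley) for inhibition of Dipeptidyl peptidase 4 (Rattus norvegicus), with a stated time of 6 h, at a dose of 1 mg/kg by the oral route (on this read-out lower numbers stand for less inhibition and higher numbers for more inhibition at the one dose given (going by the name of the read-out)), and stands highest of the two numbers measured, though compound 1 `CN(C)C(=O)C[C@@H]1CN[C@H](C(=O)N2CCC[C@H]2C#N)C1`, with 66%, lies close: the step of a number 10 percentage points higher from compound 1 to compound 2 (within the scatter) is within the scatter. Compound 3 `CNC(=O)[C@@H]1CN[C@H](C(=O)N2CCC[C@H]2C#N)C1` differs from compound 2 by hydrogen in place of methyl on an amide-type nitrogen. Within the data shown here, no measured step touches the amide-type nitrogen; the one step in hand, from compound 1 to compound 2, concerned the link to the saturated ring carbon and gave no change beyond the scatter. The step of a number 11 percentage points lower from compound 2 to compound 3 (beyond the scatter) is therefore expected to stay within the scatter, with no direction claimed. Compound 3 is estimated at 65%, between 40% and 85%.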

Compound 3, a percentage reported as inhibition, in the whole organism at one dose (the size of the read-out at that dose, not a potency): 75%
Compound 3: middle estimate off by 10 percentage points, on the low side; the measured number falls inside the stated range.
By their numbers in this assay, from the lowest: compounds 1, 3 and 2 (each within the scatter of the next).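

In this assay, the amide-type nitrogen carries hydrogen in place of methyl without a readable effect: a number 1 percentage points lower from compound 2 to compound 3 (within the scatter), so dimethylcarbamoyl and methylcarbamoyl cannot be told apart at this one dose. Similarly, a number 9 percentage points higher from compound 1 to compound 3 (within the scatter), which leaves all three compounds unresolved on this read-out. No evidence on the cause accompanies these results.

Open, from the compounds shown here alone, is how a longer chain such as ethyl on the amide-type nitrogen, or a primary carboxamide, would read. Also open, going by these compounds, is how a carboxylic acid or an amine on the saturated ring carbon would compare.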